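The source may report more compounds than this note shows. Statements on the series, on what has been measured and on what is new or still open speak of the compounds shown alone.

Working notes on the series.

Compound 1 `Clc1cccc(-n2cc(CSc3nc4ccccc4s3)nn2)c1` and compound 2 `Cc1ccccc1-n1cc(CSc2nc3ccccc3s2)nn1` share the core and differ only in the group on the aromatic nitrogen. In a functional assay on the whole organism (strain Albino Wistar) for inhibition, with Rattus norvegicus as the target, read by paw edema, with stated times of 1 h and 5 h, at a dose of 10 mg/kg by the oral route (on this read-out higher numbers stand for more inhibition at the one dose given (going by the name of the read-out) and lower numbers for less inhibition), compound 1 gives 39.6%, and in this assay compound 2 gives 43.4%. For the measured compounds named here, the single step between them, a number 3.8 percentage points higher from compound 1 to compound 2 (within the scatter), is within the scatter, so the two numbers are to be read as one level; compound 2 and compound 1 cannot be ranked against each other on these data.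

Compound 3 `CC1(C)OCC(Cn2cc(CSc3nc4ccccc4s3)nn2)O1` is not yet measured. It differs from compound 2 by (2,2-dimethyl-1,3-dioxolan-4-yl)methyl in place of 2-methylphenyl on an aromatic nitrogen. Going by the values given here, the only measured step, a number 3.8 percentage points higher from compound 1 to compound 2 (within the scatter), swaps one six-membered aromatic ring of carbon only for another and bears on this change only weakly: no measured pair exchanges such a ring for a five-membered non-aromatic ring with 2 hetero atoms. With nothing to point either way, the expected step of a number 5.4 percentage points lower from compound 2 to compound 3 (within the scatter) is none beyond the scatter, with a widened range to reflect the lack of a comparable step. Compound 3 is therefore estimated at 38%, range 18% to 56%.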

Compound 3, a percentage reported as inhibition, in the whole organism at one dose (the size of the read-out at that dose, not a potency): 49.1%
The estimate for compound 3 lay 11.1 percentage points below the measured number; low and high end bracket the measured number.
By their numbers in this assay, from the lowest: compounds 1, 2 and 3 (each within the scatter of the next).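

In this assay the group on the aromatic nitrogen need not be a six-membered aromatic ring of carbon only: the exchange for (2,2-dimethyl-1,3-dioxolan-4-yl)methyl gives a number 5.7 percentage points higher from compound 2 to compound 3 (within the scatter) and, against the other aryl group, a number 9.5 percentage points higher from compound 1 to compound 3 (within the scatter), so all three compounds read as one level. For the compounds shown here, the earlier pair exchanged only one six-membered aromatic ring of carbon only for another, whereas this change brings in one five-membered non-aromatic ring with 2 hetero atoms and 2 hydrogen-bond acceptors and still leaves the read-out within the scatter. Nothing measured independently of this read-out bears on how the group acts at this place.

The three groups shown do not establish whether any group on this aromatic nitrogen can move the read-out beyond the scatter, and all three values come from a single dose, so they give no potency order. An amine or a carboxylic acid on a short chain at this place, or the open diol in place of the 2,2-dimethyl-1,3-dioxolane ring, would test whether the level holds for groups of a different kind.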